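The compounds below may be only part of what the source reports. "The series", "measured", "known", "first", "only" and "open" are said of these compounds alone.

In a functional assay on the whole organism with Mus musculus as the target (on this read-out lower numbers stand for an effect already at smaller amounts and higher numbers for an effect only at larger amounts of compound), three compounds have been measured so far. Compound 1 `Cc1ccc(C23CCC(=O)N2CCCO3)c(C)c1` reaches only a limit of the assay, giving < 150 mg/kg. Compound 3 `O=C1CCC2(c3ccc(Cl)cc3)OCCCN12` gives 91.7 mg/kg in this assay. Compound 2 `O=C(CCC(=O)c1ccc(F)cc1)NCCCO` also reaches only a limit of the assay, with > 400 mg/kg. Compound 4 `Cc1ccc(C(=O)CCC(=O)NCCCO)cc1` has not yet been measured; it differs from compound 2 by methyl in place of fluoro on an aromatic carbon. No measured pair among these compounds shows what such a change does, so the step expected in this assay is none beyond the scatter, as expressed by a step that the limit leaves unreadable from compound 2 to compound 4. Compound 4 is therefore estimated at 450 mg/kg, within 200 mg/kg to 1000 mg/kg, with a good chance that the assay again reports only a limit.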

Compound 4, dose for half-maximal effect: > 300 mg/kg
Compound 4 was reported as a limit; the forecaster's own chance of this, stated with the estimate: 70%; the middle value does not contradict the limit.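

Compound 2 and compound 4 are both reported only as limits, and no step can be read between them. On these data alone, how methyl in place of fluoro on the aromatic carbon shifts the effective dose in this assay remains open.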